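Aryl variation on the shared core: outlook for compound 3

This account rests on a few compounds, and the source may have more. Where it says the series, first, only, none or still open, it means among the compounds named here.

Measured so far in a functional assay on HUVEC cells (Homo sapiens) for antiproliferative activity, read by MTT assay, with a stated time of 48 h; a lower number here means a stronger inhibitor, a higher number a weaker inhibitor:
compound 1 `Fc1ccc(/C=C/c2nnc(-c3ccc4c(c3)OCCO4)o2)cc1`: 4960 nM
compound 2 `Cc1cccc(/C=C/c2nnc(-c3ccc4c(c3)OCCO4)o2)c1`: 40600 nM

Compound 2 stands highest of the two numbers recorded in this assay; its nearest neighbour is compound 1, and the step of an 8.2-fold higher number from compound 1 to compound 2 (0.91 log units; beyond the scatter) lies beyond the scatter. Compound 3 `Clc1ccccc1/C=C/c1nnc(-c2ccc3c(c2)OCCO3)o1` has not yet been measured. The change from compound 2 to compound 3 is 2-chlorophenyl in place of 3-methylphenyl on a double-bonded chain carbon bound to a double-bonded chain carbon.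

For the measured compounds named here, only one measured step bears on this change: an 8.2-fold higher number from compound 1 to compound 2 (0.91 log units; beyond the scatter), in which replacing a halogen-bearing ring with a methyl-bearing ring on the same chain carbon raised the number by a modest amount. Compound 3 returns to a halogen-bearing ring, although the halogen is chlorine rather than fluorine and sits at a different position, so the precedent is indirect. On that basis the number for compound 3 is expected to move back down from compound 2, by the step of a 3.4-fold lower number from compound 2 to compound 3 (0.53 log units; beyond the scatter), but not necessarily all the way to compound 1.

The estimate for compound 3 in this assay is 12000 nM, with an expected range of 3000 nM to 50000 nM.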

Compound 3, half-maximal inhibitory concentration: 7710 nM
Beside the measured number, compound 3's estimate is 1.6-fold (0.19 log units) above it; low and high end bracket the measured number.
By their numbers in this assay, from the lowest: compounds 1 and 3 (each within the scatter of the next); then compound 2.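

In this assay the ring on the double-bonded chain carbon now has a third setting, and the step of a 5.3-fold lower number from compound 2 to compound 3 (0.72 log units; beyond the scatter) shows that the high number of compound 2 is not shared by every substituted phenyl at this place. The step of a 1.6-fold higher number from compound 1 to compound 3 (0.19 log units; within the scatter) lies within the scatter, so 2-chlorophenyl and 4-fluorophenyl, which differ in both halogen and ring position, cannot be told apart here, and among the three compounds only compound 2 with its 3-methylphenyl stands apart. Nothing measured on these compounds accounts for that separation.

The compounds shown leave open whether the methyl group or its ring position sets compound 2 apart, as group and position change together in both steps to it; a 3-chlorophenyl and a 2-methylphenyl would pull the two apart. Also open is how a phenyl ring carrying an amine or a carboxylic acid would read at this place, as the three rings shown bear only a halogen or a methyl group.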